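The source may hold more compounds than are shown below. What is called first, only, known or untested is meant among the compounds shown, and "the series" means these compounds.

In a functional assay on MIA PaCa-2 cells (Homo sapiens) for inhibition, read by MTT assay, with a stated time of 48 h, tested at 10 uM (on this read-out higher numbers stand for more inhibition of growth at the one concentration tested and lower numbers for less inhibition of growth), compound 3 `Cc1oc2c([C@H]3CCN(C)C[C@H]3O)c(O)cc(O)c2c(=O)c1C(O)c1csc([N+](=O)[O-])c1` gives 41%, the highest of three numbers, ahead of compound 2 `Cc1oc2c([C@H]3CCN(C)C[C@H]3O)c(O)cc(O)c2c(=O)c1C(O)c1ccc(F)c(Br)c1` at 9% and compound 1 `Cc1oc2c([C@H]3CCN(C)C[C@H]3O)c(O)cc(O)c2c(=O)c1C(O)c1ccc([N+](=O)[O-])cc1` at 2%. Compound 4 `COc1ccc(C(O)c2c(C)oc3c([C@H]4CCN(C)C[C@H]4O)c(O)cc(O)c3c2=O)cc1Br` carries 3-bromo-4-methoxyphenyl in place of 5-nitrothiophen-3-yl, a swap counted as 3-bromo-4-methoxyphenyl in place of 5-nitrothiophen-3-yl on a saturated chain carbon bound to an aromatic carbon and an oxygen on a saturated carbon. Going by the values given here, the two phenyl compounds measured so far stay close, with a number 7 percentage points higher from compound 1 to compound 2 (within the scatter). Moving to the thiophene brought large steps, a number 39 percentage points higher from compound 1 to compound 3 (beyond the scatter) and a number 32 percentage points higher from compound 2 to compound 3 (beyond the scatter). Compound 4 reverses that kind of swap, and compound 2 is its nearest relative, so a large fall is expected. The expected change is a number 29 percentage points lower from compound 3 to compound 4 (beyond the scatter). For compound 4 the estimated value is 12%, within an expected range of 3% to 30%.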

Compound 4, percent growth inhibition at one concentration: 3%
For compound 4 the middle estimate is 9 percentage points above the measured one, within the range that was stated.
By their numbers in this assay, from the lowest: compounds 1, 4 and 2 (each within the scatter of the next); then compound 3.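

In this assay, replacing 5-nitrothiophen-3-yl with 3-bromo-4-methoxyphenyl gives a number 38 percentage points lower from compound 3 to compound 4 (beyond the scatter), whereas methoxy in place of fluoro on the phenyl ring gives only a number 6 percentage points lower from compound 2 to compound 4 (within the scatter), and the comparison with the 4-nitrophenyl compound gives a number 1 percentage points higher from compound 1 to compound 4 (within the scatter). Across these three different phenyl groups the numbers stay together, and only compound 3 stands apart. Nothing available explains this gap. Still open, on these data alone, is whether the thiophene ring or its nitro group matters: a thiophene carrying an amine in place of nitro would help separate the two.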